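The compounds below may be only part of what the source reports. "The series", "measured", "known", "first", "only" and "open" are said of these compounds alone.

Measured compounds in a functional assay on DU-145 cells (Homo sapiens) for inhibition, read by trypan blue exclusion, with a stated time of 96 h; on this read-out higher numbers stand for weaker inhibition of growth and lower numbers for stronger inhibition of growth:
compound 1 `COc1ccc(/C=C(\C(=O)c2ccc(Br)cc2)S(=O)(=O)c2ccc(Br)cc2)cc1` gives 25000 nM.
compound 2 `O=C(/C(=C\c1ccc(Br)cc1)S(=O)(=O)c1ccc(Br)cc1)c1ccc(Br)cc1` gives 10000 nM.
compound 3 `O=C(/C(=C\c1ccc(Cl)cc1Cl)S(=O)(=O)c1ccc(Br)cc1)c1ccc(Br)cc1` gives 10000 nM.

Compound 2 and compound 3 sit level, with no change at the digits printed from compound 2 to compound 3 (within the scatter), and the two are together the lowest pair of the three numbers. Compound 1 stands apart from both: a 2.5-fold higher number from compound 2 to compound 1 (0.40 log units; beyond the scatter), and a 2.5-fold lower number from compound 1 to compound 3 (0.40 log units; beyond the scatter).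

The change from compound 2 to compound 1 is methoxy in place of bromo on an aromatic carbon. Its effect is the step of a 2.5-fold higher number from compound 2 to compound 1 (0.40 log units; beyond the scatter), a modest move toward weaker growth inhibition.

Compound 4 `COc1ccc(S(=O)(=O)/C(=C/c2ccc(Cl)cc2Cl)C(=O)c2ccc(Br)cc2)cc1` is not yet measured. It differs from compound 3 by methoxy in place of bromo on an aromatic carbon, the same change in the same kind of place as from compound 2 to compound 1, since the two descriptions of the place agree word for word. The cores of the two pairs differ, however: compound 3 differs from compound 2 by 2,4-dichlorophenyl in place of 4-bromophenyl on a double-bonded chain carbon bound to a double-bonded chain carbon, so the change is applied on a core carrying 2,4-dichlorophenyl rather than 4-bromophenyl. Among the compounds with values here, whether that core difference alters the response to the bromo-to-methoxy swap cannot be read from the three numbers; the only precedent is the single step from compound 2 to compound 1.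

On that precedent, compound 4 is expected to show a step of about a 2.5-fold higher number from compound 3 to compound 4 (0.40 log units; beyond the scatter) in this assay, the same size as a 2.5-fold higher number from compound 2 to compound 1 (0.40 log units; beyond the scatter), because compound 3 starts from 10000 nM. The estimate for compound 4 is therefore 25000 nM, with a plausible range from 10000 nM to 60000 nM.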

Compound 4, concentration for 50% growth inhibition: 20000 nM
Compound 4: the middle estimate sits 1.3-fold (0.10 log units) above what was measured, within the range that was stated.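

In this assay, methoxy in place of bromo on the core carrying 2,4-dichlorophenyl gives a 2.0-fold higher number from compound 3 to compound 4 (0.30 log units; within the scatter), so this step taken alone cannot be told apart from repeat measurement. Set beside the step on the core carrying 4-bromophenyl, it shows no detectable dependence on the core: the same change on two cores in this assay, a 2.5-fold higher number (0.40 log units; beyond the scatter) from compound 2 to compound 1 and a 2.0-fold higher number (0.30 log units; within the scatter) from compound 3 to compound 4, 1.3-fold (0.10 log units) apart, within the scatter of two such steps. This supports carrying the expected size of the change between these two cores, but it does not establish a firm effect on the second core, and two pairs in a single assay give no general rule for the series or any reason for the agreement.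

The compounds shown leave open whether other groups in place of bromo on this aromatic carbon, such as an amine, a carboxylic acid or a longer alkoxy chain, would give steps of similar size on both cores. They also leave open whether the agreement would hold on cores carrying other groups in place of 4-bromophenyl or 2,4-dichlorophenyl, and whether it would extend beyond this assay.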